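The source may hold more compounds than are shown below. What is called first, only, known or untested is meant among the compounds shown, and "the series" means these compounds.

Compound 1 `CN1C(=O)CN(C2CCCC2)c2nc(Nc3ccc(N4CCCCC4)cc3)ncc21` is the reference point of this set: in a functional assay on HT-29 cells (Homo sapiens) for inhibition, read by MTT assay, with a stated time of 48 h (on this read-out higher numbers stand for weaker inhibition and lower numbers for stronger inhibition), compound 1 gives 9860 nM. Compound 2 `CC1CCN(c2ccc(Nc3ncc4c(n3)N(C3CCCC3)CC(=O)N4C)cc2)CC1` differs from it by a single change, (methyl in place of hydrogen on a saturated ring carbon). For compound 2 this assay reports only a limit, > 30000 nM. The step of an at least 3.0-fold higher number from compound 1 to compound 2 (0.48 log units; beyond the scatter) therefore cannot be sized beyond a lower bound, since one of the three values sits at the limit of > 30000 nM in this assay, at which 1 of the 3 values shown sits.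

Compound 3 `CCN1C(=O)CN(C2CCCC2)c2nc(Nc3ccc(N4CCCCC4)cn3)ncc21` carries a different core; the difference between the two cores is not broken down here. In this assay compound 3 gives 22000 nM, the highest of the two numbers, with compound 1 as the nearest value.

Compound 4 `CCN1C(=O)CN(C2CCCC2)c2nc(Nc3ccc(N4CCC(C)CC4)cn3)ncc21` has not yet been measured. It differs from compound 3 by methyl in place of hydrogen on a saturated ring carbon, the same change made from compound 1 to compound 2, at the same place. On that pairing alone, the expected step of a 2.5-fold higher number from compound 3 to compound 4 (0.40 log units; beyond the scatter) rests on an at least 3.0-fold higher number from compound 1 to compound 2 (0.48 log units; beyond the scatter). Because compound 3 already gives 22000 nM, such a step would probably carry compound 4 to a still higher number, and compound 4 is estimated at 55000 nM, within 22000 nM to 150000 nM.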

Compound 4, half-maximal inhibitory concentration: > 30000 nM
Compound 4: no number, only a limit; the forecaster's own chance of this, stated with the estimate: 70%; the middle value does not contradict the limit.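

In this assay compound 4 gives > 30000 nM, which is a limit of the assay and not a number. Read against compound 3, this leaves only a floor for the step, an at least 1.3-fold higher number from compound 3 to compound 4 (0.13 log units; that floor lies within the scatter), so going from piperidin-1-yl to 4-methylpiperidin-1-yl gives no sign of a lower number on this core, although the floor alone does not establish a higher one. The change therefore cannot be said to carry over from one core to the other with the same size, nor to differ in size: the same change on two cores in this assay, an at least 3.0-fold higher number (0.48 log units; beyond the scatter) from compound 1 to compound 2 and an at least 1.3-fold higher number (0.13 log units; that floor lies within the scatter) from compound 3 to compound 4; the limit leaves it open whether they differ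

What the compounds shown leave open is whether a group other than methyl on the same saturated ring carbon, such as a hydroxyl, an amine, a carboxylic acid or a longer chain, would give a measurable number on either core. The methyl compounds offer no such number, and both stand at the ceiling of the assay: the limit of > 30000 nM in this assay, at which 2 of the 4 values shown sit.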